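Bromo in place of chloro: notes on compound 3

The source may report more compounds than this note shows. Statements on the series, on what has been measured and on what is new or still open speak of the compounds shown alone.

Measured so far in a functional assay on HL-60 cells (Homo sapiens) for cytotoxicity, read by luminescence and CellTiter-Glo, with a stated time of 3 days (on this read-out lower numbers stand for stronger inhibition and higher numbers for weaker inhibition), for two compounds:
- compound 1 `O=C(Nc1ccc(OC(F)(F)F)c(Cl)c1)c1cc(F)ccc1O` gives 550 nM
- compound 2 `O=C(Nc1ccc(Cl)c(Cl)c1)c1cc(F)ccc1O` gives 660 nM

Going by the values given here, compound 2 sits within the scatter of compound 1, the only other number available, with a 1.2-fold higher number from compound 1 to compound 2 (0.08 log units; within the scatter) for chloro in place of trifluoromethoxy on an aromatic carbon. Compound 3 `O=C(Nc1ccc(Br)c(Cl)c1)c1cc(F)ccc1O` carries bromo in place of chloro on an aromatic carbon, ortho to a chloro group and para to a large group (bromo in place of chloro on an aromatic carbon). Among the compounds with values here, with a 1.2-fold higher number from compound 1 to compound 2 (0.08 log units; within the scatter) as the only measured step bearing on this change, no step beyond the scatter is expected in this assay here. The estimate for compound 3 is 560 nM (expected range 250 nM to 1250 nM). That estimate means an expected 1.2-fold lower number from compound 2 to compound 3 (0.07 log units; within the scatter) for this change.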

Compound 3, half-maximal inhibitory concentration: 600 nM
Compound 3: the middle estimate sits 1.1-fold (0.03 log units) below what was measured; the range from low to high includes it.
By their numbers in this assay, from the lowest: compounds 1, 3 and 2 (each within the scatter of the next).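

In this assay the exchange of chloro for bromo gives a 1.1-fold lower number from compound 2 to compound 3 (0.04 log units; within the scatter) and the exchange of trifluoromethoxy for bromo gives a 1.1-fold higher number from compound 1 to compound 3 (0.04 log units; within the scatter) at the same aromatic carbon. This position therefore now carries three groups, trifluoromethoxy, chloro and bromo, with no step beyond the scatter among compound 1, compound 2 and compound 3. No measurement at hand speaks to the reason for this.

Still open, from the compounds shown here alone, is whether an amine, a carboxylic acid or a longer chain at this carbon would also stay within the scatter. These three compounds set no limit on what the position tolerates.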